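Thiazolyl ketone sulfides on the pyrimidinone core: antiproliferative notes

The source may report more compounds than this note shows. Statements on the series, on what has been measured and on what is new or still open speak of the compounds shown alone.

Measured so far:
compound 1, `COc1ccc(-c2nc(C)c(C(=O)CSc3nc(-c4ccc(OC)c(OC)c4)c(C#N)c(=O)[nH]3)s2)cc1`, 57.6%
compound 2, `Cc1nc(-c2ccccc2)sc1C(=O)CSc1nc(-c2cccc(Cl)c2)c(C#N)c(=O)[nH]1`, 83.7%

In a functional assay on U-87MG ATCC cells for antiproliferative activity against U-87 MG (Homo sapiens), read by MTT assay, with a stated time of 48 h, tested at 10 uM (a higher number here means a weaker effect of the compound at the concentration tested, a lower number a stronger effect), compound 2 gives 83.7%, the highest of the two numbers, and the gap to compound 1 lies beyond the scatter. Compound 3, `COc1ccc(-c2nc(SCC(=O)c3sc(-c4ccccc4)nc3C)[nH]c(=O)c2C#N)cc1OC`, is not yet measured. It differs from compound 2 in one place: 3,4-dimethoxyphenyl in place of 3-chlorophenyl on an aromatic carbon. The same 3,4-dimethoxyphenyl is carried by compound 1, whose value in this assay is 57.6%, the lower of the two; compound 1 also carries a methoxy group on its thiazole aryl ring, which compound 3 does not, so the two known points do not isolate the change under study.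

A step downward is expected, of moderate size, a number 15.7 percentage points lower from compound 2 to compound 3 (beyond the scatter), and it is not certain to exceed the scatter. Compound 3 is estimated at 68% in this assay, with a range from 50% to 86%.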

Compound 3, a percentage reported as activity, at one concentration (the size of the read-out at that concentration, not a potency): 69.8%
Estimate against measurement, compound 3: 1.8 percentage points below; measured number inside the range.
By their numbers in this assay, from the lowest: compound 1; then compound 3; then compound 2.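

In this assay, 3,4-dimethoxyphenyl in place of 3-chlorophenyl on the aromatic carbon next to the ring nitrogen gives a number 13.9 percentage points lower from compound 2 to compound 3 (beyond the scatter), so with the thiazole aryl ring unchanged, this position responds to the aryl group it carries. With 3,4-dimethoxyphenyl kept, hydrogen in place of methoxy on the thiazole aryl ring gives a number 12.2 percentage points higher from compound 1 to compound 3 (beyond the scatter), so the gap between the two earlier compounds now separates into two single changes, each beyond the scatter. Nothing measured gives a reason for either step.

These are readings at one concentration and give no potency, and the two methoxy groups of 3,4-dimethoxyphenyl are not separated from each other. From the compounds shown here alone, how a carboxylic acid or an aminomethyl group on this aryl ring would read remains open.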